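Cyclohexyl in Place of Cyclohexylmethyl on the Amine Nitrogen

A few compounds are considered here, and "the series" means these few. Any claim that something is new, unique, unknown or untested is made for them only; others in the source may bear on it.

Measured compounds:
Compound 1, `c1cncc(CN(CCCCN(C[C@H]2Cc3ccccc3CN2)[C@H]2CCCc3cccnc32)Cc2cccnc2)c1`: > 30000 nM
Compound 2, `c1ccc2c(c1)CN[C@@H](CN(CCCCNCC1CCCCC1)[C@H]1CCCc3cccnc31)C2`: > 30000 nM

In a functional assay on cells for agonist activity at C-X-C chemokine receptor type 4 (Homo sapiens), read by fluorescence and calcium flux, with a stated time of 90 s (on this read-out lower numbers stand for an effect already at smaller amounts and higher numbers for an effect only at larger amounts of compound), compound 1 gives only a limit, > 30000 nM. In this assay compound 2 likewise gives only a limit, > 30000 nM. For the measured compounds named here, compound 2 thus stands at the limit of > 30000 nM in this assay, at which 2 of the 2 values shown sit, and no step between measured compounds exists that would show how a change on the amine nitrogen moves this read-out. Compound 3, `c1ccc2c(c1)CN[C@@H](CN(CCCCNC1CCCCC1)[C@H]1CCCc3cccnc31)C2`, differs from compound 2 by cyclohexyl in place of cyclohexylmethyl on an amine nitrogen. With both measured compounds sitting at the limit, there is no basis for expecting a shift beyond the scatter, and compound 3 is expected most likely to return a limit as well. Compound 3 is estimated at 30000 nM, with a range of 10000 nM to 100000 nM. The expected step is a number no higher from compound 2 to compound 3 (the limit leaves the size open), no change beyond the scatter.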

Compound 3, half-maximal effective concentration: > 30000 nM
Compound 3: a limit, no number; the forecaster's own chance of this, stated with the estimate: 80%; the middle value lies on the limit itself.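

In this assay compound 3 gives only a limit, > 30000 nM. For the compounds shown here, compound 2 also gives only a limit, and no step between compound 2 and compound 3 can be read. The compounds shown leave open whether cyclohexyl in place of cyclohexylmethyl on the amine nitrogen changes this read-out at all.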